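The source may hold more compounds than are shown below. What is called first, only, known or untested is meant among the compounds shown, and "the series" means these compounds.

Working notes on a small set tested in a functional assay on HT-29 cells (Homo sapiens) for antiproliferative activity, with a stated time of 48 h; on this read-out higher numbers stand for weaker inhibition and lower numbers for stronger inhibition. Compound 1 `CCNC(=O)NCc1ccc(C(C)(C)C)cc1` reaches only a limit of the assay: in this assay compound 1 gives > 100000 nM, a limit and not a number. Compound 2 `CCCCC(O)c1cccc(NC(=O)NC(=O)CC)c1` likewise stops at a limit, giving > 100000 nM in this assay. Compound 3 `CCCCC(OC)c1cccc(NC(=O)CCCCl)c1` gives > 100000 nM in this assay, again a limit. Hence (the limit of > 100000 nM in this assay, at which 3 of the 3 values shown sit), and compound 1 stands nowhere in particular among the three, since none of the values can be ordered against another. Among the measured compounds shown here, no step between measured compounds that differ in one place is available, so nothing measured shows the size of any single change.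

Compound 4 `C=CC(=O)NCc1ccc(C(C)(C)C)cc1` is not yet measured. It differs from compound 1 by vinyl in place of ethylamino on a carbonyl carbon, so that the ethylcarbamoyl of compound 1 becomes a vinylcarbonyl. For the measured compounds named here, whether this change moves the read-out cannot be read from the three limits, as no measured pair touches this carbonyl carbon. The working expectation is a step of a number no higher from compound 1 to compound 4 (the limit leaves the size open) in this assay, none beyond the scatter. Compound 4 is estimated at 100000 nM, with a range from 20000 nM to 300000 nM, a limit rather than a number being the more likely outcome.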

Compound 4, half-maximal inhibitory concentration: > 100000 nM
Compound 4 was reported as a limit; the forecaster's own chance of this, stated with the estimate: 70%; the middle value sits exactly at the limit.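

Among the compounds shown here, compound 1 and compound 4 both stop at a limit, so no step between them can be read, and the size of the change to vinyl in place of ethylamino on a carbonyl carbon stays unknown: the limit of > 100000 nM in this assay, at which 4 of the 4 values shown sit. The compounds shown leave open which structural change, if any, would give a measurable value in this assay.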